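The source may report more compounds than this note shows. Statements on the series, on what has been measured and on what is new or still open speak of the compounds shown alone.

Measured so far in a toxicity assay on L02 cells (Homo sapiens) for cytotoxicity, read by MTT assay, with a stated time of 72 h (a lower number here means a stronger inhibitor, a higher number a weaker inhibitor), are these compounds
Compound 1 `O=C1c2c[n+]([O-])c3ccccc3c2C(=O)c2c1c1ccccc1n2Cc1cn(C[C@H](O)CO)nn1` gives 1130 nM
Compound 2 `CC1(C)OCC(Cn2cc(Cn3c4c(c5ccccc53)C(=O)c3c[n+]([O-])c5ccccc5c3C4=O)nn2)O1` gives 120 nM
Compound 3 `CCCCN1CCN(CCCCn2c3c(c4ccccc42)C(=O)c2c[n+]([O-])c4ccccc4c2C3=O)CC1` gives 5690 nM

In this assay compound 2 holds the lowest number of the three at 120 nM, with compound 1 nearest and compound 3 furthest. Compound 4 `CC1(C)OC[C@@H](Cn2cc(Cn3c4c(c5ccccc53)C(=O)c3c[n+]([O-])c5ccccc5c3C4=O)nn2)O1` has not yet been measured. Its difference from compound 2 is the two compounds have the same atoms and bonds; at least one stereo element is drawn with a configuration in one of them and without one in the other: 1 of 1 stereo elements differ; a stereocentre at a saturated ring carbon is drawn without a configuration in compound 2 and R in compound 4, so the two compounds have the same atoms and bonds, and a stereocentre at a saturated ring carbon is drawn without a configuration in compound 2 and R in compound 4.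

For the measured compounds named here, only one measured step touches compound 2, namely a 9.4-fold lower number from compound 1 to compound 2 (0.97 log units; beyond the scatter), where 2,2-dimethyl-1,3-dioxolan-4-yl stands in place of 1,2-dihydroxyethyl. That step changes the atoms themselves and gives only indirect guidance here. Going by the values given here, no measured pair differs in configuration alone, so the data offer no size for such a change. Going by these compounds, nothing beyond the scatter is therefore expected in this assay, although a shift in either direction remains open. The expected outcome is no change at the digits printed from compound 2 to compound 4 (within the scatter) in this comparison. For compound 4 the estimated value is 120 nM, with an expected range from 55 nM to 280 nM in this assay.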

Compound 4, half-maximal inhibitory concentration: 2900 nM
For compound 4 the middle estimate is 24-fold (1.38 log units) below the measured one, and the stated range ends below it.
By their numbers in this assay, from the lowest: compound 2; then compound 1; then compounds 4 and 3 (each within the scatter of the next).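

In this assay the record now holds a 24-fold higher number from compound 2 to compound 4 (1.38 log units; beyond the scatter) with no atom or bond changed, so the stereocentre at the saturated ring carbon of the 2,2-dimethyl-1,3-dioxolan-4-yl group proves to be a place where the drawn configuration goes with a large shift in the number. The exchange of 1,2-dihydroxyethyl for that group also loses its single direction: against a 9.4-fold lower number from compound 1 to compound 2 (0.97 log units; beyond the scatter) now stands a 2.6-fold higher number from compound 1 to compound 4 (0.41 log units; beyond the scatter), so what the exchange does in this assay depends on which of the two compounds carries the group. The gap between compound 2 and compound 4 can be traced to one structural point only: the fact that one of compounds 2 and 4 is drawn with a defined configuration and the other without, at the place where they differ.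

The compounds shown leave open how a compound drawn S at this ring carbon would stand, and with it what the undefined drawing of compound 2 represents. They also leave open whether an amine or a carboxylic acid in place of 2,2-dimethyl-1,3-dioxolan-4-yl, on the saturated chain carbon bound to an aromatic nitrogen, would move the number in either direction.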